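Acetoxymethyl in place of phenyl on the core of compound 1

A few compounds are considered here, and "the series" means these few. Any claim that something is new, unique, unknown or untested is made for them only; others in the source may bear on it.

Compound 1 `CCS[C@@H]1[C@H](SCC)[C@@H](Cn2cc(-c3ccccc3)nn2)O[C@H]1n1ccc(=O)[nH]c1=O` is the starting point. In a functional assay on HeLa cells (Homo sapiens) for cytotoxicity, read by MTT assay, with a stated time of 72 h (on this read-out lower numbers stand for an effect already at smaller amounts and higher numbers for an effect only at larger amounts of compound), compound 1 gives 6590 nM, the lowest of the two numbers recorded, and its nearest neighbour is compound 2 `CCS[C@@H]1[C@H](SCC)[C@@H](Cn2cc(-c3ccccc3C(F)(F)F)nn2)O[C@H]1n1ccc(=O)[nH]c1=O`, which gives 32800 nM. Compound 3 `CCOC(=O)c1cn(C[C@H]2O[C@@H](n3ccc(=O)[nH]c3=O)[C@H](SCC)[C@@H]2SCC)nn1` reaches only a limit of this assay, >= 100000 nM. Compound 4 `CCS[C@@H]1[C@H](SCC)[C@@H](Cn2cc(COC(C)=O)nn2)O[C@H]1n1ccc(=O)[nH]c1=O` differs from compound 1 by acetoxymethyl in place of phenyl on an aromatic carbon.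

Within the data shown here, two measured steps bear on this change. The step of a 5.0-fold higher number from compound 1 to compound 2 (0.70 log units; beyond the scatter) keeps a phenyl in place and still raises the number. The step of an at least 15-fold higher number from compound 1 to compound 3 (1.18 log units; beyond the scatter) exchanges the phenyl for a group without a ring, and the number runs into (the limit of >= 100000 nM in this assay, at which 1 of the 3 values shown sits). Compound 4 likewise gives up the phenyl for a group without a ring, so a large rise in this assay is expected, toward or possibly beyond that limit rather than within the scatter.

Compound 4 is therefore estimated at 50000 nM, with a range from 15000 nM to 150000 nM. That estimate means an expected step of a 7.6-fold higher number from compound 1 to compound 4 (0.88 log units; beyond the scatter), with a real chance that only a limit is reported.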

Compound 4, half-maximal effective concentration: >= 100000 nM
Compound 4 gave a limit, no number; the forecaster's own chance of this, stated with the estimate: 40%; middle value at least 2.0-fold (0.30 log units) away from the limit.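

Exchanging the phenyl on this aromatic carbon for acetoxymethyl gives, in this assay, an at least 15-fold higher number from compound 1 to compound 4 (1.18 log units; beyond the scatter), so the loss seen with ethoxycarbonyl is not confined to that one group: a second group with no ring behaves the same way within what this read-out can show. The result also places the new group behind the substituted aryl group, with an at least 3.0-fold higher number from compound 2 to compound 4 (0.48 log units; beyond the scatter), so the phenyl bearing trifluoromethyl, though worse than plain phenyl, still outperforms acetoxymethyl at this position. Among the compounds shown, both groups without a ring now end at the same limit, which is a limit and not a number, while both groups with a phenyl ring give numbers: the limit of >= 100000 nM in this assay, at which 2 of the 4 values shown sit.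

The step between compound 3 and compound 4 cannot be read, both values being limits, so the two groups without a ring stay unranked. The compounds shown also leave open whether the aromatic ring itself is what counts, which a cyclohexyl ring, a pyridine ring or a plain butyl chain on this carbon would help to separate.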